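Replacing 4-chlorophenyl with 3-nitrophenyl on the shared core

The source may report more compounds than this note shows. Statements on the series, on what has been measured and on what is new or still open speak of the compounds shown alone.

In a physicochemical assay for lipophilicity, measured as octanol-water partition (a higher number here means a more lipophilic compound, a lower number a more polar compound), compound 1 `CC1=C(C(=O)OCc2ccccn2)C(c2cccc(O)c2)C2=C(CCCC2=O)N1` reads 1.58 and compound 2 `COc1ccc(C2C(C(=O)OCc3ccccn3)=C(C)NC3=C2C(=O)CCC3)cc1` reads 1.9 while compound 3 `CC1=C(C(=O)OCc2ccccn2)C(c2ccc(Cl)cc2)C2=C(CCCC2=O)N1` reads 2.24 and stands highest of the three. Compound 4 `CC1=C(C(=O)OCc2ccccn2)C(c2cccc([N+](=O)[O-])c2)C2=C(CCCC2=O)N1` is still unmeasured. It has 3-nitrophenyl in place of 4-chlorophenyl on a saturated ring carbon and keeps the rest of the core unchanged. Three measured steps alter the group at this same carbon. These are a number 0.66 log units higher from compound 1 to compound 3 (beyond the scatter) and a number 0.34 log units higher from compound 2 to compound 3 (beyond the scatter) and a number 0.32 log units higher from compound 1 to compound 2 (beyond the scatter) and all are modest and beyond the scatter. No measured compound carries the 3-nitrophenyl group, so its place in this order is not shown directly. Compound 3 holds the top value, and the nearest guide to the size of a move away from it is a number 0.34 log units higher from compound 2 to compound 3 (beyond the scatter) read in reverse. A modest fall is therefore expected, an estimated a number 0.34 log units lower from compound 3 to compound 4 (beyond the scatter) in this assay for this change. The estimate for compound 4 is 1.9 with an expected range (1.5 to 2.3).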

Compound 4, partition coefficient: 1.88
For compound 4 the middle estimate is 0.02 log units above the measured one, and the stated range covers the measured number.
By their numbers in this assay, from the lowest: compounds 1, 4 and 2 (each within the scatter of the next, the first and the last beyond it); then compound 3.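

At this saturated ring carbon, 3-nitrophenyl in place of 4-chlorophenyl gives a number 0.36 log units lower from compound 3 to compound 4 (beyond the scatter) in this assay, which leaves compound 3 alone as the highest of the four. The 3-nitrophenyl group does not separate from either remaining group, with a number 0.02 log units lower from compound 2 to compound 4 (within the scatter) and a number 0.30 log units higher from compound 1 to compound 4 (within the scatter) on record, even though a number 0.32 log units higher from compound 1 to compound 2 (beyond the scatter) sets those two neighbours apart. No supporting measurement is available to explain any of these steps.

Going by these compounds, whether these readings depend on where the substituent sits on the phenyl ring stays open: the nitro, chloro, hydroxy and methoxy groups each appear in one place only. Also open, on these data alone, is what this assay would show for an amine or a carboxylic acid on that phenyl ring.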